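Compound 2 and the step to compound 3

The source may hold more compounds than are shown below. What is called first, only, known or untested is meant among the compounds shown, and "the series" means these compounds.

Compound 1 `CN(C)C1(C)CN(c2c(F)cc3c(=O)c(C(=O)O)cn(C4CC4)c3c2F)C1`: 23.6 ug/mL
Compound 2 `CNC1CN(c2c(F)cc3c(=O)c(C(=O)O)cn(C4CC4)c3c2F)C1`: 1.7 ug/mL

In a physicochemical assay for solubility, at pH 7.4 (on this read-out lower numbers stand for lower solubility and higher numbers for higher solubility), compound 2 gives 1.7 ug/mL, the lower of the two numbers, and compound 1 stands at 23.6 ug/mL.

The next compound is compound 3 `C[C@@H]1[C@@H](N(C)C)CN1c1c(F)cc2c(=O)c(C(=O)O)cn(C3CC3)c2c1F`. Its change from compound 2 is a group of 8 heavy atoms (6 carbon, 2 nitrogen; one four-membered non-aromatic ring with 1 hetero atom) in place of a group of 6 heavy atoms (4 carbon, 2 nitrogen; one four-membered non-aromatic ring with 1 hetero atom), on an aromatic carbon. The 3-(methylamino)azetidin-1-yl group leaves, and the new group, which has no common name, takes its place on the same aromatic carbon, ortho to two fluoro groups.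

Among the measured compounds shown here, only one measured step bears on this: a 14-fold lower number from compound 1 to compound 2 (1.14 log units; beyond the scatter), a large step that put 3-(methylamino)azetidin-1-yl in place of 3-(dimethylamino)-3-methylazetidin-1-yl. Compound 3 gives up that same group, so a rise in this assay is expected, probably a large one, though perhaps not the full size of that step. For the measured compounds named here, no measured compound carries the entering group, so this remains an uncertain reading of a single step.

For compound 3 the expected value is 15 ug/mL, with an estimated range of 4 ug/mL to 50 ug/mL. This estimate amounts to an expected 8.8-fold higher number from compound 2 to compound 3 (0.95 log units; beyond the scatter).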

Compound 3, solubility: 97.1 ug/mL
The estimate for compound 3 lay 6.5-fold (0.81 log units) below the measured number, and the stated range ends below it.
By their numbers in this assay, from the lowest: compound 2; then compound 1; then compound 3.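

In this assay the group on this aromatic carbon, ortho to two fluoro groups, gives a 57-fold higher number from compound 2 to compound 3 (1.76 log units; beyond the scatter) when the 3-(methylamino)azetidin-1-yl group, with 1 hydrogen-bond donor, gives way to a group of 8 heavy atoms with 0 hydrogen-bond donors and 2 defined stereocentres. The comparison with the other measured group of the same size adds something new: there is a 4.1-fold higher number from compound 1 to compound 3 (0.61 log units; beyond the scatter) even though the two groups match in heavy atoms (6 carbon, 2 nitrogen) and in their four-membered non-aromatic ring with 1 hetero atom, so those counts alone do not fix the number at this position. Nothing available here gives a measured reason for either difference between these groups.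

The compounds shown leave open which part of the entering group carries the change, since its methyl group, its dimethylamino group and its two stereocentres all differ together from the leaving group. On these data alone, it also remains open how the other stereoisomers of this group would read, and whether a primary amine on the same ring, or a piperazine in its place, would follow compound 3 or compound 2.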